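Aminophenyl-bearing series: effect of a second methoxy

The compounds below may be only part of what the source reports. "The series", "measured", "known", "first", "only" and "open" are said of these compounds alone.

Measured compounds in a functional assay on L1210 cells (Mus musculus) for inhibition, read by cell counting, with a stated time of 2 days; a lower number here means a stronger inhibitor, a higher number a weaker inhibitor:
compound 1, `Nc1cccc(-c2cn3nc(Cc4ccccc4)sc3n2)c1`, gives 7400 nM.
compound 2, `COc1ccc(Cc2nn3cc(-c4cccc(N)c4)nc3s2)cc1`, gives 227000 nM.
compound 3, `C=C(Br)C(=O)Nc1cccc(-c2cn3nc(-c4cccc(OC)c4)sc3n2)c1`, gives 580 nM.

Compound 3 stands lowest of the three numbers, with compound 1 nearest and compound 2 furthest. The difference between the core of compound 1 and the core of compound 3 is not broken down here.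

One change recurs. From compound 1 to compound 2 it is methoxy in place of hydrogen on an aromatic carbon, and the step was a 31-fold higher number from compound 1 to compound 2 (1.49 log units; beyond the scatter). Compound 4, `C=C(Br)C(=O)Nc1cccc(-c2cn3nc(-c4ccc(OC)c(OC)c4)sc3n2)c1`, awaits measurement in this assay; it differs from compound 3 by methoxy in place of hydrogen on an aromatic carbon. This is the same kind of change, not the same: in compound 4 the entering methoxy is ortho to a methoxy group, which the place in compound 2 does not have.

For compound 4 the expected step is a 5.2-fold higher number from compound 3 to compound 4 (0.71 log units; beyond the scatter), a weakening, because the same kind of change gave a 31-fold higher number from compound 1 to compound 2 (1.49 log units; beyond the scatter), though with a different surrounding the full size of that step is not assumed. The estimate for compound 4 is 3000 nM, between 800 nM and 15000 nM.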

Compound 4, half-maximal inhibitory concentration: 42 nM
Estimate against measurement, compound 4: 71-fold (1.85 log units) above; the whole stated range lies above it.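

In this assay the added methoxy gave a 14-fold lower number from compound 3 to compound 4 (1.14 log units; beyond the scatter), a strengthening, where the earlier step was a 31-fold higher number from compound 1 to compound 2 (1.49 log units; beyond the scatter), a weakening. The change therefore does not carry over between these two cores, in direction or in size: the same change on two cores in this assay, a 31-fold higher number (1.49 log units; beyond the scatter) from compound 1 to compound 2 and a 14-fold lower number (1.14 log units; beyond the scatter) from compound 3 to compound 4, 420-fold (2.63 log units) apart, beyond the scatter of two such steps

Among these compounds, this does not show what sets the difference, since there is only one pair on each side, the two pairs differ from each other in more than one place, and the entering methoxy in compound 4 is ortho to a methoxy group while the one in compound 2 is not.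

The compounds shown leave open whether the gain seen with 3-methoxyphenyl to 3,4-dimethoxyphenyl depends on the methoxy already present or would also appear with a hydroxy group, a fluorine or a longer ethoxy chain at that place. Going by these compounds, it also remains open whether the same change would strengthen or weaken on a core carrying the free amine.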